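The source may report more compounds than this note shows. Statements on the series, on what has been measured and on what is new or still open speak of the compounds shown alone.

Compound 1, `Cc1oc(-c2c(Cl)cccc2Cl)nc1CN1CCC(C(=O)NCCCN2C[C@H](C)C[C@H](C)C2)CC1`, was run in an ADME assay on microsomes from liver (Rattus norvegicus) for metabolic stability, read by LC-MS, using NADPH, at 37 degrees C (a lower number here means that the compound disappears faster, a higher number that the compound lasts longer), where compound 1 gives 0.0483 h. Among the measured compounds shown here, of the two compounds measured so far, compound 1 stands lowest. The other measured compound, compound 2, `Cc1ccccc1-c1nc(CN2CCC(C(=O)NCCCCN3C[C@H](C)C[C@H](C)C3)CC2)c(C)o1`, gives 0.2 h in this assay, a gap that lies beyond the scatter of repeated measurements; compound 2 differs from compound 1 in more than one place, so no single change can be tied to that gap. Compound 3, `Cc1cc(C)cc(-c2nc(CN3CCC(C(=O)NCCCN4C[C@H](C)C[C@H](C)C4)CC3)c(C)o2)c1`, has not yet been measured. The change from compound 1 to compound 3 is 3,5-dimethylphenyl in place of 2,6-dichlorophenyl on an aromatic carbon. For the measured compounds named here, no measured pair isolates this change, so its effect is uncertain. Compound 3 is expected to show a step of a 1.4-fold higher number from compound 1 to compound 3 (0.16 log units; within the scatter) that is small, upward if anything, and likely within the scatter. Compound 3 is therefore estimated at 0.07 h, with a range from 0.025 h to 0.2 h.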

Compound 3, half-life: < 0.5 h
Compound 3 was reported as a limit (the forecaster's own chance of this, stated with the estimate: 5%); the middle value lies beyond the limit too.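

In this assay, among the compounds shown here, compound 3 gives < 0.5 h, which is a limit of the assay and not a number, so no step between compound 1 and compound 3 can be read. The compounds shown leave open whether 3,5-dimethylphenyl in place of 2,6-dichlorophenyl changes the half-life, and in which direction.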